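The compounds below may be only part of what the source reports. "The series", "measured", "known", "first", "only" and "open" are said of these compounds alone.

Measured so far:
compound 1 `ClCc1cccc(Cn2cnc3ncnc(Cl)c32)c1`: 34700 nM
compound 2 `ClCc1ccccc1Cn1cnc2ncnc(Cl)c21`: 5490 nM
compound 3 `ClCc1ccc(Cn2cnc3c(Cl)nc(Cl)nc32)cc1`: 3800 nM

In a functional assay on RPMI-8226 cells (Homo sapiens) for cytotoxicity, read by sulforhodamine B assay, with a stated time of 48 h (a higher number here means a weaker inhibitor of growth, a lower number a stronger inhibitor of growth), compound 2 gives the second highest of the three numbers. Compound 3 lies nearest, within the scatter; compound 1 lies furthest, beyond it. Compound 4 `ClCc1ccccc1Cn1cnc2nc(Cl)nc(Cl)c21` differs from compound 2 by a single exchange: chloro in place of hydrogen on an aromatic carbon. Going by the values given here, no measured pair isolates this exchange, so no step is known. The expectation for the step from compound 2 to compound 4 in this assay is a small change, if any, inside or just beyond the scatter a 1.4-fold lower number from compound 2 to compound 4 (0.14 log units; within the scatter). Compound 4 is therefore estimated at 4000 nM, with a range from 1500 nM to 12000 nM.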

Compound 4, concentration for total growth inhibition: 630 nM
For compound 4 the middle estimate is 6.3-fold (0.80 log units) above the measured one; the measured number lies below the stated range.
By their numbers in this assay, from the lowest: compound 4; then compounds 3 and 2 (each within the scatter of the next); then compound 1.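

In this assay, going by these compounds alone, an 8.7-fold lower number from compound 2 to compound 4 (0.94 log units; beyond the scatter) is the only single-place step available. It shows that the aromatic carbon between two ring nitrogen atoms is not a silent position: one chloro in place of hydrogen moves the number beyond the scatter. Nothing available accounts for this step.

Open, going by these compounds, is whether an amine, a methoxy group or a fluoro at the same carbon would give a similar step. Also open, on these data alone, is whether the same exchange on compound 1 gives a step of like size.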